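Pyrrolidinylmethyl Extension of the Benzylic Amine in Compound 1

The source may hold more compounds than are shown below. What is called first, only, known or untested is meant among the compounds shown, and "the series" means these compounds.

Compound 1: `CC[C@H](C)C(N)c1cc(C(F)(F)F)ccc1N1CCN(C(=O)CCc2ccc(Cl)cc2Cl)CC1` — 75 nM
Compound 2: `CC(C)C[C@H](N)c1cc(C(F)(F)F)ccc1N1CCN(C(=O)CCc2ccc(S(C)(=O)=O)cc2)CC1` — 4900 nM

In an assay on HEK293 cells for displacement of a labelled ligand from Melanocortin receptor 4 (Homo sapiens) (a lower number here means a stronger inhibitor, a higher number a weaker inhibitor), compound 1 gives 75 nM, the lowest of the two numbers recorded. Compound 2 differs from it in more than one place, and in this assay compound 2 gives 4900 nM, a gap that lies beyond the usual scatter; nothing more can be read from that pair.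

The step under study leads from compound 1 to compound 3, `CCC(C)[C@H](NC[C@H]1CCCN1)c1cc(C(F)(F)F)ccc1N1CCN(C(=O)CCc2ccc(Cl)cc2Cl)CC1`, which has not yet been measured in this assay. The change is 2-methyl-1-(((pyrrolidin-2-yl)methyl)amino)butyl in place of 1-amino-2-methylbutyl on an aromatic carbon. The shared core, the trifluoromethyl group and the rest of the molecule are untouched.

With no single-change comparison available, the step is expected to be small, toward a lower number, and close to the scatter: a 1.5-fold lower number from compound 1 to compound 3 (0.18 log units; within the scatter). Compound 3 is thus estimated at 50 nM, within a range from 10 nM to 300 nM.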

Compound 3, inhibition constant: 110 nM
Estimate against measurement, compound 3: 2.2-fold (0.34 log units) below; measured number inside the range.
By their numbers in this assay, from the lowest: compounds 1 and 3 (each within the scatter of the next); then compound 2.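

The step swaps the 1-amino-2-methylbutyl group of compound 1 for the 2-methyl-1-(((pyrrolidin-2-yl)methyl)amino)butyl group of compound 3, and this assay records a 1.5-fold higher number from compound 1 to compound 3 (0.17 log units; within the scatter). Among these compounds, this is the first single-change comparison at this position, ortho to a large group, and it shows that the larger group, with its five-membered non-aromatic ring, leaves the number within the scatter of the parent, so the two compounds cannot be told apart here. Nothing available accounts for this result.

The compounds shown leave open whether a piperidine ring, a morpholine ring or an open dimethylaminoethyl chain on the same nitrogen would give a similar number. They also leave open whether the pyrrolidin-2-ylmethyl extension would behave the same way with the methylsulfonyl-bearing aryl group of compound 2.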